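The source may hold more compounds than are shown below. What is called first, only, known or untested is meant among the compounds shown, and "the series" means these compounds.

Compound 1 `C[C@@H](O)[C@H](NC(=O)CN(c1nc(Cl)nc2[nH]cnc12)C1CC1)C(=O)OCc1ccccc1` was tested in a functional assay on the whole organism (Tail, strain ICR) with Mus musculus as the target, in the tail flick test, with a stated time of 150 min, at a dose of 25 umol/kg by the oral route (on this read-out lower numbers stand for a weaker effect and higher numbers for a stronger effect at the one dose given), where compound 1 gives 12.8%. Among the three compounds measured, this is the lowest number. Compound 2 `CC[C@H](C)[C@H](NC(=O)CN(c1ncnc2c1ncn2C1CCCCO1)C1CC1)C(=O)OCc1ccccc1` gives 16.4% in this assay, which lies within the scatter of compound 1. Compound 3 `C[C@@H](O)[C@H](NC(=O)CN(c1nc(Cl)nc2[nH]cnc12)C1CC1)C(=O)O` gives 24% in this assay, and the gap to compound 1 is beyond the scatter: a number 11.2 percentage points higher from compound 1 to compound 3 (beyond the scatter).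

Compound 4 `NC(=O)CC[C@H](NC(=O)CN(c1nc(Cl)nc2[nH]cnc12)C1CC1)C(=O)OCc1ccccc1` has not been measured. It differs from compound 1 in one place: 2-carbamoylethyl in place of 1-hydroxyethyl on a saturated chain carbon bound to an amide-type nitrogen and a carbonyl carbon. The 1-hydroxyethyl group leaves and a 2-carbamoylethyl group enters, on a saturated chain carbon bound to an amide-type nitrogen and a carbonyl carbon.

Within the data shown here, the only measured step, from compound 1 to compound 3, changes a different place, the oxygen next to a carbonyl group, so it does not bear directly on this change. Among the measured compounds shown here, no measured pair shows what exchanging the side group on that chain carbon does. Without such a comparison, the expectation for compound 4 is a step within the scatter, in no firm direction, with a wide range on either side: a number 2.2 percentage points higher from compound 1 to compound 4 (within the scatter). Compound 4 is therefore estimated at 15%, with a range from 4% to 32%.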

Compound 4, a percentage reported as activity, at one dose (the size of the read-out at that dose, not a potency): 31.1%
Beside the measured number, compound 4's estimate is 16.1 percentage points below it, within the range that was stated.
By their numbers in this assay, from the lowest: compounds 1, 2, 3 and 4 (each within the scatter of the next, the first and the last beyond it).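

Among these compounds, this is the first measured comparison at the saturated chain carbon bound to an amide-type nitrogen and a carbonyl carbon, and in this assay putting 2-carbamoylethyl in place of 1-hydroxyethyl gives a number 18.3 percentage points higher from compound 1 to compound 4 (beyond the scatter). The read-out at this one dose therefore responds to the side group on that carbon, and the exchange does not lower it. The two groups differ in what is counted, with 5 heavy atoms and a double bond outside aromatic rings in the entering group against 3 heavy atoms and a defined stereocentre in the leaving one, but they have the same hydrogen-bond donor and acceptor counts, and no measurement here explains the step.

Going by these compounds, it remains open whether the step follows the longer chain or its amide end, and a plain propyl chain or a 2-carboxyethyl group on the same carbon would help separate the two. On these data alone, it is also open whether the step would hold in a free carboxylic acid, with hydrogen in place of benzyl on the oxygen, or at other doses and times.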